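A few compounds are considered here, and "the series" means these few. Any claim that something is new, unique, unknown or untested is made for them only; others in the source may bear on it.

In a functional assay on the whole organism with Mus musculus as the target (a higher number here means that more compound is needed for the effect, a lower number that less compound is needed), compound 1 `CN(C)C(=O)/C=C1\CCc2ccc(F)cc21` gives > 100 mg/kg, which is a limit of the assay and not a number. Compound 2 `CN(C)C(=O)/C=C1\CCc2c(F)cc(F)cc21` gives 50 mg/kg and compound 3 `O=C(/C=C1\CCc2cc(F)cc(F)c21)NC1CC1` gives 69 mg/kg. For the measured compounds named here, these two values lie within the scatter of each other, and they are the only true numbers so far.

Compound 4 `CC(C)NC(=O)/C=C1\CCc2c(F)cc(F)cc21` has isopropylamino in place of dimethylamino on a carbonyl carbon. Going by the values given here, the one measured step, an at least 2.0-fold lower number from compound 1 to compound 2 (0.30 log units; that floor lies within the scatter), is a fluoro in place of hydrogen on an aromatic carbon, so it does not touch this group, and its floor lies within the scatter. Among the compounds with values here, no measured step isolates a change on the carbonyl carbon. Compound 3 has another group there and gives 69 mg/kg, but it differs from compound 2 in more than one place, so it offers only loose guidance.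

No shift beyond the scatter is therefore expected in this assay. The expected change is a 1.1-fold higher number from compound 2 to compound 4 (0.04 log units; within the scatter), an estimate that stays within the scatter. For compound 4 the estimated value is 55 mg/kg, with an expected range of 25 mg/kg to 120 mg/kg.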

Compound 4, dose for half-maximal effect: 50 mg/kg
For compound 4 the middle estimate is 1.1-fold (0.04 log units) above the measured one; low and high end bracket the measured number.
By their numbers in this assay, from the lowest: compounds 2, 4 and 3 (each within the scatter of the next). At a limit, above all of these: compound 1.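

In this assay, the carbonyl carbon now has its first comparison that differs in one place only, and isopropylamino in place of dimethylamino gives no change at the digits printed from compound 2 to compound 4 (within the scatter). The dimethylcarbamoyl group of compound 2 has no hydrogen-bond donor and the isopropylcarbamoyl group of compound 4 has one, yet this difference leaves the printed number the same, so on this core the position accepts the change in this assay. Both compounds give true numbers, which makes this step easier to read than the earlier one, whose size is only a floor: the limit of > 100 mg/kg in this assay, at which 1 of the 4 values shown sits.

On these data alone, it remains open whether a cyclic amine such as morpholine or a longer chain such as n-butylamino on the carbonyl carbon would also leave the number in place. A single exchange of this kind cannot show how far that tolerance extends.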